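Plasma free fraction with an ether in place of a ring amine

A few compounds are considered here, and "the series" means these few. Any claim that something is new, unique, unknown or untested is made for them only; others in the source may bear on it.

Measured so far:
- compound 1 `CC(=O)Nc1cc(-c2ccc(N(C)C(=O)c3c(F)cccc3Cl)c(N3CC4CC4C3)c2)n(C2CCC2)n1`: 0.0004
- compound 2 `CC(=O)Nc1cc(-c2ccc(N(C)C(=O)c3c(F)cccc3Cl)c(N3CCCCC3)c2)n(C(C)C)n1`: 0.001

In an ADME assay on a cell-free system (plasma, Rattus norvegicus) (on this read-out lower numbers stand for a smaller free fraction and higher numbers for a larger free fraction), compound 2 gives 0.001, the highest of the two numbers, with compound 1 giving the lower number at 0.0004. Compound 3 `CC(=O)Nc1cc(-c2ccc(N(C)C(=O)c3c(F)cccc3Cl)c(OCC(C)C)c2)n(C(C)C)n1` differs from compound 2 by one change, (isobutoxy in place of piperidin-1-yl on an aromatic carbon). Among the compounds with values here, no measured pair here shows what this change does in this assay, so a step from compound 2 to compound 3 of any size beyond the scatter is not expected; the expected step is no change at the digits printed from compound 2 to compound 3 (within the scatter). Compound 3 is therefore estimated at 0.001, within a range from 0.0004 to 0.003.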

Compound 3, unbound fraction: 0.002
Compound 3: middle estimate off by 2.0-fold (0.30 log units), on the low side, and the stated range covers the measured number.
By their numbers in this assay, from the lowest: compound 1; then compounds 2 and 3 (each within the scatter of the next).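

In this assay, within the data shown here, putting isobutoxy in place of piperidin-1-yl on this aromatic carbon gives a 2.0-fold higher number from compound 2 to compound 3 (0.30 log units; within the scatter) and so offers the first direct comparison at this position. An open chain joined through oxygen can therefore stand where the ring amine stood without a step beyond the scatter. No measurement offered here explains this result. Still open, from the compounds shown here alone, is how a shorter methoxy group, a longer chain or a carboxylic acid would read at this carbon. This single pair also leaves open whether the step would hold on another core.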